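The compounds below may be only part of what the source reports. "The series", "measured", "known", "first", "only" and "open" are said of these compounds alone.

Of the compounds shown here, two of a shared core have been tested in a functional assay on the whole organism with Mus musculus as the target, in the rotarod test; on this read-out higher numbers stand for an effect only at larger amounts of compound and lower numbers for an effect already at smaller amounts. Compound 1, `NC(=O)/C=C1\CCc2ccc(Cl)cc21`, carries a chloro group on its aromatic ring; in this assay compound 1 gives 221 mg/kg. Compound 2, `O=C(/C=C1\CCc2c(F)ccc(F)c21)NC1CC1`, differs from compound 1 in more than one place, and in this assay compound 2 gives 2 mg/kg. Of the two numbers, that of compound 1 is the highest, and the gap to compound 2 is beyond the usual scatter, so compound 2 acts at smaller amounts. Since the two structures differ at several places at once, the comparison does not tell which change is responsible.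

Compound 3, `NC(=O)/C=C1\CCc2ccccc21`, is not yet measured. It differs from compound 1 by a single change: hydrogen in place of chloro on an aromatic carbon. No comparison of two measured compounds isolates this change, so there is nothing to lean on beyond compound 1 itself. My expectation is that the step of a 1.0-fold lower number from compound 1 to compound 3 (0.00 log units; within the scatter) stays within the usual scatter, with no clear direction. For compound 3 the estimated value in this assay is 220 mg/kg, in a range from 80 mg/kg to 600 mg/kg.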

Compound 3, dose for half-maximal effect: 164 mg/kg
Compound 3: middle estimate off by 1.3-fold (0.13 log units), on the high side; the measured number falls inside the stated range.
By their numbers in this assay, from the lowest: compound 2; then compounds 3 and 1 (each within the scatter of the next).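

Hydrogen in place of chloro on this aromatic carbon, which is meta to a fused ring and para to a fused ring, gives a 1.3-fold lower number from compound 1 to compound 3 (0.13 log units; within the scatter) in this assay and so leaves the two compounds indistinguishable on this read-out. For the compounds shown here, this is the first direct view of the position, since the earlier comparison between compound 1 and compound 2 mixed several changes and could not isolate any one of them. On the core of compound 1, then, the chloro group can be left out without a change that this whole-animal test can detect, and the large number of compound 1 cannot be pinned on that chloro group. The data offer nothing that would explain this outcome.

From the compounds shown here alone, whether a larger or quite different group on this carbon, such as methoxy, a nitrile or an amine, would also leave the number in place remains open. Also open, going by these compounds, is whether the same swap would read the same way on a compound with a cyclopropyl group on the amide nitrogen, like compound 2, where a single step could show how much this position matters at much smaller doses.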